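The source may hold more compounds than are shown below. What is called first, only, known or untested is meant among the compounds shown, and "the series" means these compounds.

Of the compounds shown here, three have been measured in a functional assay on CHO cells for agonist activity at Alpha-1A adrenergic receptor (Homo sapiens), read by fluorescence and calcium flux; on this read-out higher numbers stand for an effect only at larger amounts of compound and lower numbers for an effect already at smaller amounts. Compound 1 `CS(=O)(=O)Nc1c(Cl)ccc2c1CCCC2c1ncc[nH]1` gives 43 nM. Compound 2 `CS(=O)(=O)Cc1cccc2c1CCC2c1ncc[nH]1` gives 84 nM. Compound 3 `CCOCc1cccc2c1CCC2c1ncc[nH]1` gives 62 nM. Within the data shown here, the one step between measured compounds that differ in a single place is a 1.4-fold lower number from compound 2 to compound 3 (0.13 log units; within the scatter). Compound 3 thus stands second among the three numbers, and its gaps to compound 2 and to compound 1 both fall within the scatter, so no order among the three can be read from these figures.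

Compound 4 `COCCc1cccc2c1CCC2c1ncc[nH]1` has not yet been measured. It differs from compound 3 by methoxymethyl in place of ethoxy on a saturated chain carbon bound to an aromatic carbon, so the same atoms are present, only joined differently. Among the measured compounds shown here, the one measured step that bears on this position is the step from compound 2 to compound 3, which stayed within the scatter even though it swapped groups of quite different kind. For the smaller rearrangement leading to compound 4, no step beyond the scatter is expected in this assay, which is to say a 1.0-fold higher number from compound 3 to compound 4 (0.02 log units; within the scatter). Compound 4 is therefore estimated at 65 nM, within a range from 25 nM to 170 nM.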

Compound 4, half-maximal effective concentration in the Alpha-1A adrenergic receptor assay: 168 nM
Beside the measured number, compound 4's estimate is 2.6-fold (0.41 log units) below it; the range from low to high includes it.
By their numbers in the Alpha-1A adrenergic receptor assay, from the lowest: compounds 1, 3, 2 and 4 (each within the scatter of the next, the first and the last beyond it).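

In the Alpha-1A adrenergic receptor assay compound 3 gives 62 nM and compound 4 gives 168 nM; the same atoms joined differently, ethoxymethyl becoming 2-methoxyethyl, give a 2.7-fold higher number from compound 3 to compound 4 (0.43 log units; beyond the scatter), a modest but real change. This position therefore registers how the chain is joined, and not only which atoms it carries, which the earlier comparison of compound 2 and compound 3 could not show. Compound 2 is not separated from either ether in the Alpha-1A adrenergic receptor assay, with a 2.0-fold higher number from compound 2 to compound 4 (0.30 log units; within the scatter), while in a physicochemical assay for lipophilicity, at pH 7.4 (on this read-out higher numbers stand for higher lipophilicity and lower numbers for lower lipophilicity), compound 3 gives 2.1 and compound 4 gives 2, with a number 0.10 log units lower from compound 3 to compound 4 (within the scatter), so the two ethers differ in the Alpha-1A adrenergic receptor assay but not measurably in the physicochemical assay.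

On these data alone, whether an amine or a longer chain at this place would sit nearer compound 3 or compound 4 remains open. The compounds shown offer no measured reason for the step between the two ethers.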